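The source may hold more compounds than are shown below. What is called first, only, known or untested is meant among the compounds shown, and "the series" means these compounds.

Measured compounds:
Compound 1, `COc1cc(-c2nnc3n2NC(c2ccco2)C(C(=O)c2ccccc2F)S3)cc(OC)c1OC`, in a functional assay on A549 cells (Homo sapiens) for cytotoxicity, read by MTT assay, with a stated time of 48 h (on this read-out lower numbers stand for stronger inhibition and higher numbers for weaker inhibition), gives 78700 nM.
Compound 2, `COc1cc(-c2nnc3n2NC(c2ccco2)C(C(=O)c2ccccc2)S3)cc(OC)c1OC`, in this assay gives 33400 nM.
Compound 3, `COc1cc(-c2nnc3n2NC(c2ccco2)C(C(=O)c2ccc(F)c(F)c2)S3)cc(OC)c1OC`, in this assay gives 93700 nM.

Compound 3 stands at the highest number of the three; its gap to compound 1 is within the scatter, while the step of a 2.8-fold higher number from compound 2 to compound 3 (0.45 log units; beyond the scatter) is beyond it. Compound 4, `COc1cc(-c2nnc3n2NC(c2ccco2)C(C(=O)c2ccc(C(F)(F)F)cc2)S3)cc(OC)c1OC`, is not yet measured. The change from compound 3 is 4-(trifluoromethyl)phenyl in place of 3,4-difluorophenyl on a carbonyl carbon. For the measured compounds named here, two measured steps bear on it: a 2.4-fold lower number from compound 1 to compound 2 (0.37 log units; beyond the scatter) shows that taking fluoro away lowers the number, and a 2.8-fold higher number from compound 2 to compound 3 (0.45 log units; beyond the scatter) shows that adding two fluoro atoms raises it, whereas a 1.2-fold higher number from compound 1 to compound 3 (0.08 log units; within the scatter) stays within the scatter. Both fluorine-bearing compounds sit above the unsubstituted one. Compound 4 again carries fluorine in the entering group, so in this assay no step beyond the scatter is expected, a 1.0-fold lower number from compound 3 to compound 4 (0.02 log units; within the scatter). For compound 4 the estimate in this assay is 90000 nM, with a range from 40000 nM to 200000 nM.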

Compound 4, half-maximal inhibitory concentration: 37200 nM
Compound 4: middle estimate off by 2.4-fold (0.38 log units), on the high side; measured number outside the range, below it.
By their numbers in this assay, from the lowest: compounds 2 and 4 (each within the scatter of the next); then compounds 1 and 3 (each within the scatter of the next).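

In this assay, fluorine in the group on the carbonyl carbon does not by itself go with the higher numbers: a 2.5-fold lower number from compound 3 to compound 4 (0.40 log units; beyond the scatter) and a 2.1-fold lower number from compound 1 to compound 4 (0.33 log units; beyond the scatter) are both beyond the scatter, whereas a 1.1-fold higher number from compound 2 to compound 4 (0.05 log units; within the scatter) stays within it. The groups at this position therefore fall into two sets, with 4-(trifluoromethyl)phenyl alongside unsubstituted phenyl and apart from 2-fluorophenyl and 3,4-difluorophenyl. No available evidence accounts for this split.

On these data alone, it remains open whether the split follows the kind of fluorine substituent or its place on the ring, which a 4-fluorophenyl group would help to test. As far as these compounds go, it is also open whether a group without fluorine, such as 4-methoxyphenyl or 4-aminophenyl, would bring the number clearly below that of compound 2, at 33400 nM.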